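Dropping a Methyl from a Pyridyl Triazine Antiproliferative

The source may report more compounds than this note shows. Statements on the series, on what has been measured and on what is new or still open speak of the compounds shown alone.

Four close relatives built on one shared core are compared here. Compound 1 `C=CC(=O)Nc1cccc(Nc2ncnc(Nc3ccc(-c4ccc(C)nc4)cc3)n2)c1` carries an acrylamide and a 6-methylpyridin-3-yl group at the far end. Compound 2 `C=CC(=O)N1CCc2ccc(Nc3ncnc(Nc4ccc(C(=O)N5CCCCC5)cc4)n3)cc21` places the acrylamide on a fused bicyclic amine and a piperidine amide at the other end, and compound 3 `CC#CC(=O)Nc1cccc(Nc2ncnc(Nc3ccc(C(=O)N4CCCCC4)cc3)n2)c1` keeps that piperidine amide while bearing a butynamide. All were tested, or are to be tested, in a functional assay on Ramos cells (Homo sapiens) for antiproliferative activity, read by CCK-8 assay, with a stated time of 24 h; a lower number here means a stronger inhibitor, a higher number a weaker inhibitor.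

Among the measured compounds shown here, only one number is reported so far: in this assay compound 3 gives 24400 nM, a weak result. In this assay compound 1 gives "not determined" (no result reported), and in the same assay compound 2 gives "not determined" (no result reported), so compound 1 stands without any number to anchor it.

Compound 4 `C=CC(=O)Nc1cccc(Nc2ncnc(Nc3ccc(-c4cccnc4)cc3)n2)c1` differs from compound 1 in a single spot: hydrogen in place of methyl on an aromatic carbon. Nothing measured connects these two, so the size of the step can only be guessed; a change this small is expected to stay within the scatter of this assay, with no clear direction. Given the weak activity of compound 3 in this assay at 24400 nM, compound 4 is estimated at 12000 nM, ranging from 1500 nM to 100000 nM.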

Compound 4, half-maximal inhibitory concentration: > 100000 nM
Compound 4: no number, only a limit; the forecaster's own chance of this, stated with the estimate: 25%; middle value at least 8.3-fold (0.92 log units) from the limit.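

In this assay compound 4 gives > 100000 nM, which is a limit and not a number. Among the compounds shown here, compound 1 has no single number here, and no step between compound 1 and compound 4 can be read. On these data alone, whether going from 6-methylpyridin-3-yl to pyridin-3-yl shifts the result in this assay, and in which direction, stays open.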